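The source may hold more compounds than are shown below. What is called first, only, known or untested is meant among the compounds shown, and "the series" means these compounds.

Series notes. Compound 2 `CC(C)(C)CC[C@H](c1ccc(C(=O)NCc2nn[nH]n2)cc1)N1C(=O)C(c2cccc(C(F)(F)F)c2)=N[C@]12CC[C@@H](C(C)(C)C)CC2` and compound 1 `C[C@H](c1ccc(C(=O)NCCC(=O)O)cc1)N1C(=O)C(c2cccc(OC(F)(F)F)c2)=N[C@]12CC[C@@H](C(C)(C)C)CC2` have been run in an assay on membranes from liver for displacement of a labelled ligand from Glucagon receptor (Mus musculus), read by scintillation counting, with a stated time of 60 min; a higher number here means a weaker inhibitor, a lower number a stronger inhibitor. In this assay compound 1 gives 1500 nM. Compound 2 gives 140 nM, the lowest of the two numbers, and the two compounds differ in more than one place, so only their two values can be compared. Compound 3 `CC(C)(C)CC[C@H](c1ccc(C(=O)NCc2nn[nH]n2)cc1)N1C(=O)C(c2cnccc2C(F)(F)F)=N[C@]12CC[C@@H](C(C)(C)C)CC2` is not yet measured; it differs from compound 2 by 4-(trifluoromethyl)pyridin-3-yl in place of 3-(trifluoromethyl)phenyl on a carbon with a double bond to nitrogen. Within the data shown here, no measured pair shows this change, so the step from compound 2 to compound 3 is expected to be small, a 1.6-fold higher number from compound 2 to compound 3 (0.20 log units; within the scatter), within or near the scatter. Compound 3 is estimated at 220 nM, range 80 nM to 600 nM.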

Compound 3, half-maximal inhibitory concentration: 96 nM
The estimate for compound 3 lay 2.3-fold (0.36 log units) above the measured number; the range from low to high includes it.
By their numbers in this assay, from the lowest: compounds 3 and 2 (each within the scatter of the next); then compound 1.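

Setting 4-(trifluoromethyl)pyridin-3-yl in place of 3-(trifluoromethyl)phenyl on the carbon with a double bond to nitrogen gives, in this assay, a 1.5-fold lower number from compound 2 to compound 3 (0.16 log units; within the scatter). Among these compounds, this is the first single-place comparison: at this position, a six-membered aromatic ring with 1 hetero atom and 1 hydrogen-bond acceptor reads the same as the all-carbon ring. Nothing measured here gives a reason for this result.

On these data alone, whether this position also accepts a nitrile or an amine in place of trifluoromethyl remains open. The separate contributions of the several differences between compound 1 and compound 2 cannot be read.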